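The compounds below may be only part of what the source reports. "The series", "measured", "known", "first", "only" and "open" are said of these compounds alone.

Measured compounds, with their results in a functional assay for inhibition, with Rattus norvegicus as the target; on this read-out higher numbers stand for weaker inhibition and lower numbers for stronger inhibition:

compound 1, `CCCCc1cc(OC)c2ccccc2c1OC(C)=O`, gives 440 nM
compound 2, `CCc1c(CC)c(OC(C)=O)c2ccccc2c1OC`, gives 400 nM
compound 3, `CCCCc1ccc2c(OC(C)=O)c(CCCC)cc(OC)c2c1`, gives 480 nM

The three measured compounds in this assay sit close together, and none of the gaps between them is large enough to read as a real difference. Compound 1 and compound 3 differ in one place only: butyl in place of hydrogen on an aromatic carbon. The step that goes with this change is a 1.1-fold higher number from compound 1 to compound 3 (0.04 log units; within the scatter), so on this read-out the added butyl group has made no visible difference.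

Compound 2 carries the same atoms as compound 1, joined differently; the difference between the two cores is not broken down here. Compound 2 and compound 1 show values that lie within the usual scatter of one another, so nothing can be said about which core is favoured.

Compound 4, `CCCCc1ccc2c(OC(C)=O)c(CC)c(CC)c(OC)c2c1`, is not yet measured. It stands to compound 2 as compound 3 stands to compound 1: butyl in place of hydrogen on an aromatic carbon. The place lines for the two changes read the same word for word, so this is the same change on a different core. From that single measured instance, the step from compound 2 to compound 4 is expected to be a 1.1-fold higher number from compound 2 to compound 4 (0.05 log units; within the scatter) in this assay, resting on the flat step a 1.1-fold higher number from compound 1 to compound 3 (0.04 log units; within the scatter). That precedent is one measurement only. The range for compound 4 is kept wide. Compound 4 is therefore estimated at 450 nM in this assay, expected to lie between 220 nM and 900 nM.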

Compound 4, half-maximal inhibitory concentration: 940 nM
For compound 4 the middle estimate is 2.1-fold (0.32 log units) below the measured one; measured number above the stated range.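

In this assay, butyl in place of hydrogen on an aromatic carbon now has a second reading, on the core of compound 2, where it gives a 2.4-fold higher number from compound 2 to compound 4 (0.37 log units; beyond the scatter) and so a modest loss of inhibition. Set beside the reading on the core of compound 1, this step cannot be told apart from the earlier one: the same change on two cores in this assay, a 1.1-fold higher number (0.04 log units; within the scatter) from compound 1 to compound 3 and a 2.4-fold higher number (0.37 log units; beyond the scatter) from compound 2 to compound 4, 2.2-fold (0.33 log units) apart, within the scatter of two such steps. The change can therefore be carried between these two cores with no demonstrated dependence on the core, but a single pair of steps does not prove that its effect is the same on both, and it does not settle whether the butyl group costs inhibition in general, since one step is flat and the other is modest.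

On these data alone, only hydrogen and butyl are compared at this place, so it remains open how a shorter chain such as methyl, a longer chain such as hexyl, or a polar group such as an amine or a carboxylic acid would read there. The acetoxy group is common to all four compounds, which leaves open what a free hydroxyl group in its place would do to inhibition on either core.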